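Swapping a Fluorophenyl for a Cyanophenyl: Expecting Little Change

This account rests on a few compounds, and the source may have more. Where it says the series, first, only, none or still open, it means among the compounds named here.

Measured compounds:
compound 1, `Clc1cc2[nH]nc(-c3cnn(-c4ccccc4)c3)c2cc1N[C@@H]1CCNC1`, 668 nM
compound 2, `Fc1ccc(-n2cc(-c3n[nH]c4cc(Cl)c(N[C@@H]5CCNC5)cc34)cn2)cc1`, 684 nM

In an assay on HEK293 cells for displacement of a labelled ligand from tyrosine-protein kinase receptor UFO (Homo sapiens), read by NanoBRET, with a stated time of 2 h (a lower number here means a stronger inhibitor, a higher number a weaker inhibitor), compound 1 gives 668 nM, and compound 2 gives 684 nM. Compound 2 has the higher of the two numbers, but the step of a 1.0-fold higher number from compound 1 to compound 2 (0.01 log units; within the scatter) sits well within the scatter of this assay, so the two compounds cannot be told apart by these measurements.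

Compound 3, `N#Cc1ccccc1-n1cc(-c2n[nH]c3cc(Cl)c(N[C@@H]4CCNC4)cc23)cn1`, has not yet been measured. It differs from compound 2 in one place: 2-cyanophenyl in place of 4-fluorophenyl on an aromatic nitrogen. For the measured compounds named here, only one measured step touches this part of the molecule, namely a 1.0-fold higher number from compound 1 to compound 2 (0.01 log units; within the scatter), and it shows that changing the group on this phenyl from hydrogen to fluorine produced no step beyond the scatter. Going by the values given here, the change to compound 3 is a bigger one, replacing the whole phenyl group with a different substituted phenyl, and no measured pair shows what a nitrile here does. The expectation is therefore a step of a 1.0-fold higher number from compound 2 to compound 3 (0.01 log units; within the scatter) of no clear direction, with wide uncertainty. Compound 3 is estimated to give 700 nM, in a range from 250 nM to 2000 nM.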

Compound 3, half-maximal inhibitory concentration: 3540 nM
Estimate against measurement, compound 3: 5.1-fold (0.70 log units) below; measured number outside the range, above it.
By their numbers in this assay, from the lowest: compounds 1 and 2 (each within the scatter of the next); then compound 3.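

This result shows that the phenyl on the aromatic nitrogen is not indifferent to every change, as the earlier pair alone might have suggested. In this assay, fluoro in place of hydrogen gave only a 1.0-fold higher number from compound 1 to compound 2 (0.01 log units; within the scatter), which is within the scatter, whereas 2-cyanophenyl in place of 4-fluorophenyl gives a 5.2-fold higher number from compound 2 to compound 3 (0.71 log units; beyond the scatter), and cyano in place of hydrogen gives a 5.3-fold higher number from compound 1 to compound 3 (0.72 log units; beyond the scatter), both beyond the scatter and both toward a weaker inhibitor. The loss therefore appears from either of the two earlier compounds, which themselves cannot be told apart, but nothing available explains why this substitution weakens the compound.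

What remains open is whether the loss belongs to the nitrile itself or would follow any group placed where the nitrile sits, since compound 3 is the only compound shown with a group there. A methyl or an amine on the same ring carbon would help separate these two readings, and would show whether this part of the phenyl accepts anything larger than hydrogen.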